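The source may hold more compounds than are shown below. What is called first, only, known or untested is meant among the compounds shown, and "the series" means these compounds.

Working notes on the series. Compound 1 `CCCCCCCC/C(=C\C=C\C(=O)N[C@H](C)CCCc1cccnc1)c1ccc(OC)cc1` is the reference: in an assay (Canis lupus familiaris) for binding affinity to platelet-activating factor receptor (Homo sapiens) (on this read-out lower numbers stand for stronger inhibition and higher numbers for weaker inhibition), compound 1 gives 5 nM. Within the data shown here, compound 2 `CC/C(=C\C=C\C(=O)N[C@H](C)CCCc1cccnc1)c1ccc(OC)cc1` carries the same core with a shorter chain on the alkene carbon, and in this assay compound 2 gives 30 nM, the highest of the two numbers measured so far; its nearest neighbour is compound 1, and the step of a 6.0-fold higher number from compound 1 to compound 2 (0.78 log units; beyond the scatter) lies beyond the scatter.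

Compound 3 `COc1ccc(/C(C)=C/C=C/C(=O)N[C@H](C)CCCc2cccnc2)cc1` is not yet measured. The change from compound 2 is hydrogen in place of methyl on a saturated chain carbon bound to a double-bonded chain carbon. Among the measured compounds shown here, only the step from compound 1 to compound 2 bears on it; that step removed a much larger piece of the same chain and cost a modest amount. The present cut is far smaller, so a small rise in the number is expected, possibly within the scatter, and the step of a 1.7-fold higher number from compound 2 to compound 3 (0.22 log units; within the scatter) is the estimate. For compound 3 the expected value in this assay is 50 nM, with a range from 20 nM to 150 nM.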

Compound 3, half-maximal inhibitory concentration: 25 nM
Compound 3: the middle estimate sits 2.0-fold (0.30 log units) above what was measured; the measured number falls inside the stated range.
By their numbers in this assay, from the lowest: compound 1; then compounds 3 and 2 (each within the scatter of the next).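

In this assay, the change from ethyl to methyl at this position gives a 1.2-fold lower number from compound 2 to compound 3 (0.08 log units; within the scatter) and so does not separate the two short-chain compounds. Compound 1 stands apart from both, with a 5.0-fold higher number from compound 1 to compound 3 (0.70 log units; beyond the scatter) alongside a 6.0-fold higher number from compound 1 to compound 2 (0.78 log units; beyond the scatter) on the same read-out, so across these three compounds the separation lies between the longer chain of compound 1 and the two short chains, not between ethyl and methyl. No supporting measurement bears on why the numbers fall this way.

The compounds shown leave open at which chain length between ethyl and the chain of compound 1 the number shifts, and whether that shift is gradual or abrupt. As far as these compounds go, how a butyl chain or a chain ending in a carboxylic acid would read at this position also remains open.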